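A few compounds are considered here, and "the series" means these few. Any claim that something is new, unique, unknown or untested is made for them only; others in the source may bear on it.

Compound 1 `CC(C)c1cc(Oc2c(Br)cc3oc(C(=O)O)cc3c2Br)ccc1O` is a thyroid hormone receptor agonist measured in a functional assay on HepG2 cells for agonist activity at thyroid hormone receptor (Homo sapiens) (on this read-out higher numbers stand for an effect only at larger amounts of compound and lower numbers for an effect already at smaller amounts), where compound 1 gives 7 nM. Of the two measured compounds it has the lower number: compound 2 `CC(C)c1cc(Oc2c(C(C)C)cc(CC3SC(=O)NC3=O)cc2C(C)C)ccc1O` gives 70 nM in this assay, a difference beyond the usual scatter. Compound 3 `COc1ccc(Oc2c(Br)cc3oc(C(=O)O)cc3c2Br)cc1C(C)C` is related to compound 1 by a single change, (methyl in place of hydrogen on an oxygen on an aromatic ring), that is, hydroxy becomes methoxy. For the measured compounds named here, no measured pair shows this change directly, so the expectation rests on compound 1 alone. A step toward higher numbers, larger than the scatter, is expected, a 29-fold higher number from compound 1 to compound 3 (1.46 log units; beyond the scatter). Compound 3 is therefore estimated at 200 nM, most likely between 30 nM and 2000 nM.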

Compound 3, half-maximal effective concentration: 1000 nM
The estimate for compound 3 lay 5.0-fold (0.70 log units) below the measured number; measured number inside the range.
By their numbers in this assay, from the lowest: compound 1; then compound 2; then compound 3.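

Swapping hydroxy for methoxy adds only a methyl on an oxygen on an aromatic ring, yet it gives a 140-fold higher number from compound 1 to compound 3 (2.15 log units; beyond the scatter) in this assay. The earlier compounds shown here could not show this, and it marks this single position as highly sensitive to that small change on the core of compound 1. No available evidence accounts for the size of the step. On these data alone, whether an amine or a fluorine in place of the hydroxy would fare better remains open. So does whether the same change would cost as much on compound 2.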